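Urea-Linked Thienopyrimidines Tested for Cytotoxicity on HT-29 Cells

The compounds below may be only part of what the source reports. "The series", "measured", "known", "first", "only" and "open" are said of these compounds alone.

Measured compounds:
compound 1 `CN(C)CCNc1nc(-c2ccc(NC(=O)Nc3ccc(Cl)cc3Cl)cc2)nc2ccsc12` — 1320 nM
compound 2 `Cc1ccc(NC(=O)Nc2ccc(-c3nc(NCCN(C)C)c4sccc4n3)cc2)cc1` — 2150 nM
compound 3 `CCN(CC)CCNc1nc(-c2ccc(NC(=O)Nc3ccc(Cl)cc3Cl)cc2)nc2c(Cl)c(Cl)sc12` — 1140 nM

The three compounds were assessed in a functional assay on HT-29 cells (Homo sapiens) for cytotoxicity, read by MTT assay, with a stated time of 72 h; on this read-out higher numbers stand for weaker inhibition and lower numbers for stronger inhibition. Compound 1 gives 1320 nM and compound 2 gives 2150 nM; the change between them, (4-methylphenyl in place of 2,4-dichlorophenyl on an amide-type nitrogen), produced a 1.6-fold higher number from compound 1 to compound 2 (0.21 log units; within the scatter). Compound 3 gives 1140 nM; how its core differs from that of compound 1 is not broken down here.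

Compound 4 `CCN(CC)CCNc1nc(-c2ccc(NC(=O)Nc3ccc(C)cc3)cc2)nc2c(Cl)c(Cl)sc12` is not yet measured in this assay. It is made from compound 3 by 4-methylphenyl in place of 2,4-dichlorophenyl on an amide-type nitrogen, the same change, at the same place, as from compound 1 to compound 2. Because a 1.6-fold higher number from compound 1 to compound 2 (0.21 log units; within the scatter) was small, a step of similar size, a 1.6-fold higher number from compound 3 to compound 4 (0.20 log units; within the scatter), is expected. Compound 4 is therefore estimated at 1800 nM, with a likely range from 900 nM to 4000 nM.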

Compound 4, half-maximal inhibitory concentration: 950 nM
For compound 4 the middle estimate is 1.9-fold (0.28 log units) above the measured one; measured number inside the range.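

In this assay, putting 4-methylphenyl in place of 2,4-dichlorophenyl on the amide-type nitrogen gave a 1.2-fold lower number from compound 3 to compound 4 (0.08 log units; within the scatter). Set beside the earlier step, the change carried over from one core to the other without a difference that these measurements can separate: the same change on two cores in this assay, a 1.6-fold higher number (0.21 log units; within the scatter) from compound 1 to compound 2 and a 1.2-fold lower number (0.08 log units; within the scatter) from compound 3 to compound 4, 2.0-fold (0.29 log units) apart, within the scatter of two such steps. Among these compounds, this shows only that the change stayed small on these two cores; it does not show that either group is the better one, or that the same would hold on a further core.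

The compounds shown leave open whether the step stays small with other groups on that nitrogen, such as an unsubstituted phenyl or a cyclohexyl. They also leave open what a morpholine at the end of the side chain would do.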